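The source may hold more compounds than are shown below. What is called first, only, known or untested is meant among the compounds shown, and "the series" means these compounds.

In a functional assay on A549 cells (Homo sapiens) for cytotoxicity, read by MTT assay, with a stated time of 72 h (a higher number here means a weaker inhibitor, a lower number a stronger inhibitor), compound 3 `CC(=O)n1cc(/C=C(/C(=O)O)c2ccc(Cl)cc2)c2cc(OCc3ccccc3)ccc21` gives 52300 nM, the second highest of three numbers, all of which sit within the scatter of one another. Its nearest neighbour is compound 1 `CC(=O)n1cc(/C=C(/C(=O)O)c2ccccc2)c2cc(OCc3ccccc3)ccc21`, which gives 57500 nM, and compound 2 `CC(=O)n1cc(/C=C(/C(=O)O)c2ccc(OCc3ccccc3)cc2)c2cc(OCc3ccccc3)ccc21` gives 44100 nM. The step of a 1.1-fold lower number from compound 1 to compound 3 (0.04 log units; within the scatter) and the step of a 1.2-fold higher number from compound 2 to compound 3 (0.07 log units; within the scatter) both alter the phenyl group on the double-bonded chain carbon, and both lie within the scatter, as does a 1.3-fold lower number from compound 1 to compound 2 (0.12 log units; within the scatter). Compound 4 `COc1cc(OC)cc(/C(=C\c2cn(C(C)=O)c3ccc(OCc4ccccc4)cc23)C(=O)O)c1` carries 3,5-dimethoxyphenyl in place of 4-chlorophenyl on a double-bonded chain carbon bound to a carbonyl carbon and a double-bonded chain carbon. Since the earlier changes at that phenyl group moved nothing beyond the scatter, no step beyond the scatter is expected in this assay for compound 4 either, in neither direction. Compound 4 is therefore estimated at 50000 nM, between 22000 nM and 110000 nM, an expected step of a 1.0-fold lower number from compound 3 to compound 4 (0.02 log units; within the scatter).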

Compound 4, half-maximal inhibitory concentration: 26000 nM
Compound 4: the middle estimate sits 1.9-fold (0.28 log units) above what was measured; the range from low to high includes it.
By their numbers in this assay, from the lowest: compounds 4, 2, 3 and 1 (each within the scatter of the next, the first and the last beyond it).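

In this assay, among these compounds, the change to 3,5-dimethoxyphenyl on a double-bonded chain carbon bound to a carbonyl carbon and a double-bonded chain carbon gives the first step beyond the scatter at this position, a 2.2-fold lower number from compound 1 to compound 4 (0.34 log units; beyond the scatter) starting from phenyl, while a 2.0-fold lower number from compound 3 to compound 4 (0.30 log units; within the scatter) starting from 4-chlorophenyl stays within it. The position therefore responds only modestly, and only against the unsubstituted phenyl. Nothing measured here accounts for this step. As far as these compounds go, whether both methoxy groups are needed for it remains open, as does whether a hydroxy or amino group on that phenyl ring would move the number further.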